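The compounds below may be only part of what the source reports. "The series", "measured", "known", "first", "only" and "open" are said of these compounds alone.

In a functional assay on RAW264.7 cells (Mus musculus) for inhibition, read by Griess assay, with stated times of 3 h and 24 h (on this read-out higher numbers stand for weaker inhibition and lower numbers for stronger inhibition), compound 1 (`C=C1CC[C@H]2[C@@](C)(CC[C@@H](OC(=O)CCCC[C@@H]3CCSS3)[C@@]2(C)NC=O)[C@@H]1/C=C/C1=CCOC1=O`) gives > 50000 nM, a limit of the assay and not a number. For the measured compounds named here, compound 2 (`C=C1CC[C@H]2[C@@](C)(CC[C@@H](OC(=O)CN)[C@@]2(C)NC=O)[C@@H]1/C=C/C1=CCOC1=O`) gives > 50000 nM, likewise only a limit, and no numeric value is available so far: the limit of > 50000 nM in this assay, at which 2 of the 2 values shown sit. Compound 3 (`C=C1CC[C@H]2[C@@](C)(CC[C@@H](OC(=O)CNC)[C@@]2(C)NC=O)[C@@H]1/C=C/C1=CCOC1=O`) has methyl in place of hydrogen on an amine nitrogen. Going by the values given here, the one measured step is a step that the two limits leave unreadable from compound 1 to compound 2, a different change, and it provides no size to carry over. Compound 2 gives > 50000 nM, a limit, and on that ground the expectation in this assay is another limit for compound 3, with no step beyond the scatter in either direction. The estimated step is a number no higher from compound 2 to compound 3 (the limit leaves the size open). For compound 3 the estimated value is 50000 nM, with an expected range from 20000 nM to 100000 nM.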

Compound 3, half-maximal inhibitory concentration: > 50000 nM
Compound 3: no number, only a limit; the forecaster's own chance of this, stated with the estimate: 70%; the middle value lies on the limit itself.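

No step can be read among compound 1, compound 2 and compound 3, since each gives only a limit in this assay: the limit of > 50000 nM in this assay, at which 3 of the 3 values shown sit.

The compounds shown leave open how large any of these steps is, and which change, if any, would give a numeric value in this assay.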